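This account rests on a few compounds, and the source may have more. Where it says the series, first, only, none or still open, it means among the compounds named here.

Series notes on a physicochemical assay for solubility, read by spectrophotometry, in phosphate buffer, with a stated time of 18 h, at pH 7.4; a higher number here means a more soluble compound, a lower number a less soluble compound. Compound 1 `CCc1ccc(-c2nc3c(c(C)nn3-c3ccccc3)c(-c3ccccc3C#N)c2C#N)cc1` gives 2400 nM, compound 3 `CCc1ccc(-c2nc3c(c(C)nn3-c3ccccc3)c(-c3ccccc3Br)c2C#N)cc1` gives 1500 nM, and compound 2 `CCc1ccc(-c2nc3c(c(C)nn3-c3ccccc3)c(-c3ccccc3I)c2C#N)cc1` gives 8500 nM. Compound 1 therefore stands level with compound 3 within the scatter, while compound 2 is the highest of the three.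

Compound 4 `CCc1ccc(-c2nc3c(c(C)nn3-c3ccccc3)c(-c3ccccc3C(F)(F)F)c2C#N)cc1` is the next entry, and it differs from compound 1 as follows: trifluoromethyl in place of cyano on an aromatic carbon. This is trifluoromethyl in place of cyano on an aromatic carbon, or 2-cyanophenyl to 2-(trifluoromethyl)phenyl.

Two measured replacements of cyano at this place bear on it. Bromo gives a 1.6-fold lower number from compound 1 to compound 3 (0.20 log units; within the scatter), and iodo gives a 3.5-fold higher number from compound 1 to compound 2 (0.55 log units; beyond the scatter). Among the measured compounds shown here, these two outcomes are themselves far apart, at a 5.7-fold lower number from compound 2 to compound 3 (0.75 log units; beyond the scatter), and no trifluoromethyl compound has been measured. On these data alone, no step beyond the scatter is expected in this assay, although the range stays open upward given a 3.5-fold higher number from compound 1 to compound 2 (0.55 log units; beyond the scatter).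

The expected change is a 1.1-fold lower number from compound 1 to compound 4 (0.04 log units; within the scatter). For compound 4 the estimate is 2200 nM, with an expected range of 700 nM to 7000 nM.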

Compound 4, solubility: 11000 nM
Compound 4: the middle estimate sits 5.0-fold (0.70 log units) below what was measured; the measured number lies above the stated range.
By their numbers in this assay, from the lowest: compounds 3 and 1 (each within the scatter of the next); then compounds 2 and 4 (each within the scatter of the next).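

In this assay, trifluoromethyl in place of cyano gives a 4.6-fold higher number from compound 1 to compound 4 (0.66 log units; beyond the scatter), so compound 2 is no longer the only replacement at this position to clear the scatter upward. Trifluoromethyl and iodo stand level, with a 1.3-fold higher number from compound 2 to compound 4 (0.11 log units; within the scatter) within that scatter, whereas a 7.3-fold higher number from compound 3 to compound 4 (0.87 log units; beyond the scatter) sets trifluoromethyl well apart from bromo, and the four compounds fall into a low pair, compound 3 and compound 1, and a high pair, compound 2 and compound 4. Nothing at hand accounts for this split among the substituents.

Open, on these data alone, is where chloro or fluoro at this position would fall, with the low pair or the high pair. Also open, as far as these compounds go, is whether a group of another kind, such as an amine or a carboxylic acid, would fit either pair.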